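The source may hold more compounds than are shown below. What is called first, only, known or untested is meant among the compounds shown, and "the series" means these compounds.

Three compounds that share one core were tested in a functional assay (aorta) with Rattus norvegicus as the target; a lower number here means a stronger inhibitor, a higher number a weaker inhibitor. Compound 1 `CC1(C)Oc2ccc(C#N)cc2[C@@H](/N=C(\NC#N)Nc2ccc(Cl)cc2)[C@@H]1O` gives 1800 nM. Compound 2 `Cc1cccc(N/C(=N/[C@@H]2c3cc(C#N)ccc3OC(C)(C)[C@H]2O)NC#N)c1` gives 1000 nM, and compound 3 `Cc1ccc(N/C(=N/[C@@H]2c3cc(C#N)ccc3OC(C)(C)[C@H]2O)NC#N)cc1` gives 2700 nM. Among these three numbers compound 1 holds the second highest, but its gaps to the other two both fall within the scatter, so no ranking of compounds 1, 2 and 3 can be read from them: a 1.8-fold lower number from compound 1 to compound 2 (0.26 log units; within the scatter) and a 1.5-fold higher number from compound 1 to compound 3 (0.18 log units; within the scatter). Among the compounds with values here, only one step reaches beyond the scatter, and it is modest: a 2.7-fold higher number from compound 2 to compound 3 (0.43 log units; beyond the scatter), which changes 3-methylphenyl to 4-methylphenyl on the amine nitrogen.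

Compound 4 `CC1(C)Oc2ccc(C#N)cc2[C@@H](/N=C(\NC#N)Nc2ccc(Cl)c(Cl)c2)[C@@H]1O` has not yet been measured. It differs from compound 1 in a single place: chloro in place of hydrogen on an aromatic carbon. Within the data shown here, no measured step adds a second chloro group, so this change has no direct precedent. The nearest comparisons are the swaps of the whole ring on the amine nitrogen, which stayed within the scatter, while the methyl shift showed that where a substituent sits on that ring can matter modestly. For compound 4, the step in this assay is therefore expected to be small, in either direction, and most likely within the scatter: a 1.2-fold lower number from compound 1 to compound 4 (0.08 log units; within the scatter). Compound 4 is estimated at 1500 nM, with a range from 600 nM to 4000 nM.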

Compound 4, half-maximal inhibitory concentration: 4600 nM
Estimate against measurement, compound 4: 3.1-fold (0.49 log units) below; measured number above the stated range.
By their numbers in this assay, from the lowest: compounds 2, 1, 3 and 4 (each within the scatter of the next, the first and the last beyond it).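

Adding a chloro group to the 4-chlorophenyl ring, on an aromatic carbon ortho to the existing chloro group and meta to a large group, gives a modest but real shift in this assay (a 2.6-fold higher number from compound 1 to compound 4 (0.41 log units; beyond the scatter)). This is the first change among these compounds that adds a group to the ring instead of swapping or moving one, and it shows that this position is not neutral: the 3,4-dichlorophenyl compound is a weaker inhibitor than its 4-chlorophenyl parent, and it is also weaker than the 3-methylphenyl compound (a 4.6-fold higher number from compound 2 to compound 4 (0.66 log units; beyond the scatter)), while its gap to the 4-methylphenyl compound stays within the scatter (a 1.7-fold higher number from compound 3 to compound 4 (0.23 log units; within the scatter)). Nothing available here explains why this added chloro group has this effect.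

On these data alone, whether the same step follows with another group at this place, such as fluoro, methoxy or an amine, stays open. Also open, as far as these compounds go, is whether the new chloro group acts on its own or only together with the chloro group already on the ring.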